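Replacing the hydroxy group of compound 2

The compounds below may be only part of what the source reports. "The series", "measured", "known", "first", "only" and "open" are said of these compounds alone.

In a functional assay on A549 cells (Homo sapiens) for antiproliferative activity, read by CCK-8 assay, with a stated time of 72 h (on this read-out higher numbers stand for weaker inhibition and lower numbers for stronger inhibition), compound 2 `O=C(NO)c1ccc(COc2ccccc2)cc1` gives 28000 nM, the highest of the three numbers and so the weakest inhibition. Compound 1 `C/C(=N\O)c1ccc(OCc2ccc(C(=O)NO)cc2)cc1` gives 8930 nM, and compound 3 `O=C(/C=C/c1ccc(COc2ccccc2)cc1)NO` gives 5770 nM. In compound 4 `Nc1cc(F)ccc1NC(=O)c1ccc(COc2ccccc2)cc1`, 2-amino-4-fluorophenyl takes the place of hydroxy on an amide-type nitrogen (2-amino-4-fluorophenyl in place of hydroxy on an amide-type nitrogen). Going by the values given here, no measured step makes this change, so the evidence is only indirect. One step shows a 3.1-fold higher number from compound 1 to compound 2 (0.50 log units; beyond the scatter), and another, which also alters the hydroxycarbamoyl group, shows a 4.9-fold lower number from compound 2 to compound 3 (0.69 log units; beyond the scatter). Both are modest, and both measured neighbours of compound 2 lie lower, with compound 1 at 8930 nM and compound 3 at 5770 nM, so a modest fall is expected, though not certain. The expected change is a 2.3-fold lower number from compound 2 to compound 4 (0.37 log units; beyond the scatter). The estimate for compound 4 is 12000 nM, within a range of 3000 nM to 40000 nM.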

Compound 4, half-maximal inhibitory concentration: 8340 nM
For compound 4 the middle estimate is 1.4-fold (0.16 log units) above the measured one, within the range that was stated.
By their numbers in this assay, from the lowest: compounds 3, 4 and 1 (each within the scatter of the next); then compound 2.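

In this assay, swapping hydroxy on the amide-type nitrogen for 2-amino-4-fluorophenyl gives a 3.4-fold lower number from compound 2 to compound 4 (0.53 log units; beyond the scatter), so the hydroxy group of compound 2 is not required for activity at this position. The earlier steps shown here changed the far end of the molecule or the whole hydroxycarbamoyl group, whereas this one changes only the substituent on that nitrogen. Nothing measured here explains the change. On these data alone, whether a plain phenyl or a methyl on that nitrogen would give the same result remains open. So does the separate contribution of the amine and the fluorine on the new ring.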